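Changing the Nitrogen Substituent on the Shared Core

A few compounds are considered here, and "the series" means these few. Any claim that something is new, unique, unknown or untested is made for them only; others in the source may bear on it.

compound 1 `CC(C)n1nc(C(=O)N[C@H]2COc3ccccc3N(C)C2=S)nc1Cc1ccccc1`: 360 nM
compound 2 `CC(C)CCn1nc(C(=O)N[C@H]2COc3ccccc3N(C)C2=S)nc1Cc1ccccc1`: 3640 nM
compound 3 `CN1C(=S)[C@@H](NC(=O)c2nc(Cc3ccccc3)n(C3CCCCCC3)n2)COc2ccccc21`: 5530 nM

In a functional assay on HT-29 cells (Homo sapiens) for inhibition, read by luminescence and CellTiter-Glo, with a stated time of 24 h (on this read-out higher numbers stand for an effect only at larger amounts of compound and lower numbers for an effect already at smaller amounts), compound 2 gives 3640 nM, the second highest of the three numbers. Its nearest neighbour is compound 3, with a 1.5-fold higher number from compound 2 to compound 3 (0.18 log units; within the scatter), a gap within the scatter, while compound 1 lies furthest away, with a 10-fold higher number from compound 1 to compound 2 (1.00 log units; beyond the scatter). Compound 4 `CN1C(=S)[C@@H](NC(=O)c2nc(Cc3ccccc3)n(C3CCOC3)n2)COc2ccccc21` differs from compound 2 by oxolan-3-yl in place of isopentyl on an aromatic nitrogen. Going by the values given here, the steps that bear on this change are a 10-fold higher number from compound 1 to compound 2 (1.00 log units; beyond the scatter) and a 15-fold higher number from compound 1 to compound 3 (1.19 log units; beyond the scatter), both beyond the scatter, showing that isopropyl on that nitrogen gives the lowest number of the set. Among the compounds with values here, no measured compound carries oxolan-3-yl there, so the direction rests on this comparison alone. Compound 4 is expected to show a 3.0-fold lower number from compound 2 to compound 4 (0.48 log units; beyond the scatter), a move back toward compound 1. The estimate for compound 4 is 1200 nM, within 300 nM to 4800 nM.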

Compound 4, half-maximal effective concentration: 1580 nM
For compound 4 the middle estimate is 1.3-fold (0.12 log units) below the measured one; measured number inside the range.
By their numbers in this assay, from the lowest: compound 1; then compound 4; then compounds 2 and 3 (each within the scatter of the next).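

Oxolan-3-yl and isopentyl have the same count of heavy atoms, yet the change in this assay still moves the number beyond the scatter (a 2.3-fold lower number from compound 2 to compound 4 (0.36 log units; beyond the scatter)), so that count alone does not set the value at this nitrogen. Oxolan-3-yl also stands apart from cycloheptyl (a 3.5-fold lower number from compound 3 to compound 4 (0.54 log units; beyond the scatter)) but does not reach isopropyl (a 4.4-fold higher number from compound 1 to compound 4 (0.64 log units; beyond the scatter)), which keeps the lowest number of the four compounds. No measurement here explains these differences. The compounds shown leave open whether cyclopropyl, oxetan-3-yl or a pyrrolidin-3-yl amine would come closer to compound 1.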